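The source may hold more compounds than are shown below. What is called first, only, known or untested is meant among the compounds shown, and "the series" means these compounds.

Three compounds with the shared core have been examined in an ADME assay on HepG2 2.2.15 cells (Homo sapiens) for cytotoxicity; a higher number here means that more compound is tolerated, a lower number that less compound is tolerated. Compound 1 `CC(C)(C)OC(=O)Nc1ncc(C(Oc2ccc3cc(Br)ccc3c2)c2ccc(Cl)cc2)s1` gives only a limit there, > 50000 nM. That single value is the one sitting at the limit of > 50000 nM in this assay, at which 1 of the 3 values shown sits. Compound 2 `Clc1ccc(C(Oc2ccc3cc(Br)ccc3c2)c2cnc(NCC3CCCCC3)s2)cc1` is recorded in this assay as "not toxic" (no number reported), and compound 3 `COCCCNc1ncc(C(Oc2ccc3cc(Br)ccc3c2)c2ccc(Cl)cc2)s1` likewise as "not toxic" (no number reported), so no single number fixes where compound 3 stands; it was simply tolerated. Compound 4 `CCOC(=O)CCCNc1ncc(C(Oc2ccc3cc(Br)ccc3c2)c2ccc(Cl)cc2)s1` has not yet been measured. It differs from compound 3 by ethoxycarbonyl in place of methoxy on a saturated chain carbon, three bonds along the chain from a nitrogen on an aromatic ring. For the measured compounds named here, no step between measured compounds has been reported for this assay. Since compound 3 shows "not toxic" (no number reported), the writer expects no shift beyond the scatter in this assay for compound 4. For compound 4 the estimated half-maximal cytotoxic concentration is 50000 nM, with a range from 20000 nM to 100000 nM.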

Compound 4, half-maximal cytotoxic concentration: "not toxic" (no number reported)
The entry for compound 4 holds no number; there is nothing to compare the estimate with.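

Compound 3 and compound 4 are both recorded only as "not toxic", so no step can be read between them. The compounds shown leave open at what concentration, if any, cytotoxicity would appear in this assay.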